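From Compound 2 to Compound 3: A Propyl Chain Enters

The compounds below may be only part of what the source reports. "The series", "measured", "known", "first", "only" and "open" are said of these compounds alone.

Among the compounds with values here, compound 2 `NC[C@H]1COC(c2ccccc2)(c2ccccc2)O1` gives 1400 nM in a functional assay (brain) for displacement of a labelled ligand, with Rattus norvegicus as the target (on this read-out lower numbers stand for stronger inhibition and higher numbers for weaker inhibition), the lowest of the two numbers measured so far, while compound 1 `CCN1CCCC[C@H]1[C@H]1COC(c2ccccc2)(c2ccccc2)O1` gives 6900 nM. Compound 3 `CCC[C@H](N)[C@H]1COC(c2ccccc2)(c2ccccc2)O1` differs from compound 2 by propyl in place of hydrogen on a saturated chain carbon bound to an amine nitrogen and a saturated ring carbon. Within the data shown here, the only measured step, a 4.9-fold lower number from compound 1 to compound 2 (0.69 log units; beyond the scatter), swapped 1-ethylpiperidin-2-yl for aminomethyl. Compound 3 adds propyl on the saturated chain carbon bound to an amine nitrogen, a partial return toward bulk, so a small rise in the number is expected, a 1.6-fold higher number from compound 2 to compound 3 (0.20 log units; within the scatter). Compound 3 is estimated at 2200 nM in this assay, between 700 nM and 7000 nM.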

Compound 3, inhibition constant: 3450 nM
Compound 3: the middle estimate sits 1.6-fold (0.20 log units) below what was measured; low and high end bracket the measured number.
By their numbers in this assay, from the lowest: compound 2; then compounds 3 and 1 (each within the scatter of the next).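

Within the data shown here, this is the first look at the saturated chain carbon bound to an amine nitrogen: in this assay, propyl in place of hydrogen gives a 2.5-fold higher number from compound 2 to compound 3 (0.39 log units; beyond the scatter), a modest weakening of inhibition. Exchanging 1-ethylpiperidin-2-yl for 1-aminobutyl gives a 2.0-fold lower number from compound 1 to compound 3 (0.30 log units; within the scatter), so these two groups cannot be told apart here, whereas aminomethyl did separate from 1-ethylpiperidin-2-yl. Nothing available explains the weakening seen with propyl. Still open, going by these compounds, is how a methyl or a longer butyl chain on this carbon would compare with propyl and hydrogen.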